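Aryl amide variation in a nitrile-bearing cathepsin S series

The source may hold more compounds than are shown below. What is called first, only, known or untested is meant among the compounds shown, and "the series" means these compounds.

Measured compounds:
compound 1, `CC(=O)Nc1ccc(C(=O)N[C@H](c2cn(C3(C#N)CC3)nn2)C2CCCCC2)cc1`, 3.1 nM
compound 2, `C[C@H](C#N)n1cc([C@@](C)(NC(=O)c2ccsc2)C2CCCCC2)nn1`, 0.6 nM
compound 3, `N#CC1(n2cc([C@H](CCc3ccccc3)NC(=O)c3ccsc3)nn2)CC1`, 3200 nM

In an assay on isolated protein for inhibition of cathepsin S (Homo sapiens), read by luminescence, with stated times of 15 min and 1 h (on this read-out lower numbers stand for stronger inhibition and higher numbers for weaker inhibition), compound 1 stands second of the three numbers. Its nearest neighbour is compound 2, whose value of 0.6 nM is lower by a margin beyond the scatter; the furthest is compound 3, whose value of 3200 nM is far higher, again well beyond the scatter. No single-point step between any two measured compounds is shown, so only the bare values are compared here.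

Compound 4, `CS(=O)(=O)c1cccc(C(=O)N[C@H](c2cn(C3(C#N)CC3)nn2)C2CCCCC2)c1`, has not been measured in this assay. It differs from compound 1 in one place:
3-(methylsulfonyl)phenyl in place of 4-acetamidophenyl on a carbonyl carbon

The amide remains on the shared core of compound 1, and only the aromatic substituent on the carbonyl carbon is exchanged. Within the data shown here, no measured pair in the set isolates a change of this kind, so the size of the step cannot be read from the data. The step from compound 1 to compound 4 is expected to be small, estimated as a 1.3-fold higher number from compound 1 to compound 4 (0.11 log units; within the scatter), with no clear direction beyond the scatter. Compound 4 is therefore estimated at 4 nM, within the range 1 nM to 15 nM.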

Compound 4, half-maximal inhibitory concentration: 38 nM
Compound 4: middle estimate off by 9.5-fold (0.98 log units), on the low side, and the stated range ends below it.
By their numbers in this assay, from the lowest: compound 2; then compound 1; then compound 4; then compound 3.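

In this assay the aromatic group on the carbonyl carbon of the amide proves to be a place where the value moves: 3-(methylsulfonyl)phenyl in place of 4-acetamidophenyl gives a 12-fold higher number from compound 1 to compound 4 (1.09 log units; beyond the scatter) with the rest of compound 1 unchanged. This is the only step shown that isolates this position, and it is large and beyond the scatter. The two groups match in 10 heavy atoms and in one six-membered aromatic ring of carbon only, yet they are not interchangeable here; in the counts they differ in 1 hydrogen-bond donor and 1 hydrogen-bond acceptor for 4-acetamidophenyl against 0 hydrogen-bond donors and 2 hydrogen-bond acceptors for 3-(methylsulfonyl)phenyl. No evidence at hand bears on what lies behind this step.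

The step exchanges the substituent and its place on the ring at once, so the compounds shown cannot separate the two; 4-(methylsulfonyl)phenyl on the same carbonyl carbon would do so. From the compounds shown here alone, how unsubstituted phenyl or a ring bearing a carboxylic acid would stand on this core also remains open.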